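A side-group swap on an amide-type nitrogen

The source may hold more compounds than are shown below. What is called first, only, known or untested is meant among the compounds shown, and "the series" means these compounds.

Measured in an ADME assay on cells (Epithelial cell, Rattus norvegicus) for cytotoxicity, read by MTT assay; on this read-out higher numbers stand for weaker inhibition and lower numbers for stronger inhibition:
- compound 1 `O=C(Cn1c(=O)c(Cc2ccccc2)nc2ccccc21)NNC(=S)Nc1ccccc1`: 16.1 nM
- compound 2 `N=C(N)NS(=O)(=O)c1ccc(NC(=O)Cn2c(=O)c(Cc3ccccc3)nc3ccccc32)cc1`: 8.97 nM
- compound 3 `Nn1c(Cn2c(=O)c(Cc3ccccc3)nc3ccccc32)nnc1Cn1c(=O)c(Cc2ccccc2)nc2ccccc21`: 6.04 nM

Compound 1 stands within the scatter of compound 2, while compound 3 gives a number lower than compound 1 by more than the scatter. Compound 4 `O=C(Cn1c(=O)c(Cc2ccccc2)nc2ccccc21)N/N=C/c1ccccc1O` has not yet been measured. It keeps the core of compound 1 and differs on an amide-type nitrogen: a group of 9 heavy atoms (7 carbon, 1 nitrogen, 1 oxygen; one six-membered aromatic ring of carbon only) in place of a group of 10 heavy atoms (7 carbon, 2 nitrogen, 1 sulfur; one six-membered aromatic ring of carbon only), on an amide-type nitrogen. For the measured compounds named here, no measured pair differs in one place to guide this change. Compound 3 at 6.04 nM and compound 1 at 16.1 nM mark the whole measured span in this assay, so only a modest move toward a lower number is expected, within the scatter: the estimated 1.6-fold lower number from compound 1 to compound 4 (0.21 log units; within the scatter). For compound 4 the expected value is 10 nM, with an estimated range of 4 nM to 25 nM.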

Compound 4, half-maximal inhibitory concentration: 8.12 nM
Compound 4: the middle estimate sits 1.2-fold (0.09 log units) above what was measured, within the range that was stated.
By their numbers in this assay, from the lowest: compounds 3, 4, 2 and 1 (each within the scatter of the next, the first and the last beyond it).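

This first single-place step on the amide-type nitrogen, read in this assay, is a 2.0-fold lower number from compound 1 to compound 4 (0.30 log units; within the scatter). The two groups, each carrying one six-membered aromatic ring of carbon only, therefore cannot be told apart here, although they differ in their atoms and in their counts of hydrogen-bond donors and acceptors. No available measurement bears on the reason for this. The compounds shown leave open how a short alkyl chain, an amine or a carboxylic acid would read on this nitrogen.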